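A few compounds are considered here, and "the series" means these few. Any claim that something is new, unique, unknown or untested is made for them only; others in the source may bear on it.

Of the compounds shown here, three that share one core have been tested in a functional assay with Alpha-1B adrenergic receptor (Homo sapiens) as the target, read by calcium flux; a higher number here means a larger maximal response, a lower number a smaller maximal response. Compound 1 `Cc1ccc(-c2ccccc2NCC2=NCCN2)n1C` gives 0% in this assay. Compound 2 `Cn1cccc1-c1ccccc1NCC1=NCCN1` gives 0%. Compound 3 `CC(C)n1nccc1-c1ccccc1NCC1=NCCN1` gives 0%. Among the measured compounds shown here, the single step measured between two of them, no change at the digits printed from compound 1 to compound 2 (within the scatter), is the replacement of a methyl group by hydrogen on an aromatic carbon, and it left the maximal response where it was. Compound 2 therefore stands level with compound 1 and with compound 3 at the digits shown; none of the three differs from another beyond the scatter.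

Compound 4 `Cn1ncnc1-c1ccccc1NCC1=NCCN1` has not yet been measured. It differs from compound 2 in one place: 1-methyl-1H-1,2,4-triazol-5-yl in place of 1-methyl-1H-pyrrol-2-yl on an aromatic carbon. For the measured compounds named here, no measured step exchanges one five-membered ring for another, so the only guidance is that compound 1, compound 2 and compound 3 all sit at the same level, and that the step from compound 1 to compound 2 stayed within the scatter. The expectation for compound 4 is therefore a step of no change at the digits printed from compound 2 to compound 4 (within the scatter), none beyond the scatter. Compound 4 is estimated at 0%, between 0% and 8%.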

Compound 4, largest response reached (reported as maximal response), in percent of the reference or control that the assay uses: 93%
Estimate against measurement, compound 4: 93 percentage points below; measured number above the stated range.
By their numbers in this assay, from the lowest: compounds 1, 2 and 3 (each within the scatter of the next); then compound 4.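

In this assay the identity of the ring on this aromatic carbon matters far more than the earlier methyl change: 1-methyl-1H-1,2,4-triazol-5-yl in place of 1-methyl-1H-pyrrol-2-yl gives a number 93 percentage points higher from compound 2 to compound 4 (beyond the scatter), against no change at the digits printed from compound 1 to compound 2 (within the scatter) for hydrogen in place of methyl. Both groups are five-membered aromatic rings with 6 heavy atoms, the entering one with 3 hetero atoms and the leaving one with 1, so changing the atoms of the ring without changing its size is enough to alter the result here. Nothing measured on these compounds explains why the maximal response rises.

Going by these compounds, whether this rise belongs to the triazole alone stays open, since a tetrazole ring or an imidazole ring at this carbon cannot be judged from these compounds. Also open is what hydrogen or an ethyl group in place of the methyl on the triazole would do, as the only methyl step shown lies on the pyrrole.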